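Removing the chloro from compound 2

The source may hold more compounds than are shown below. What is called first, only, known or untested is meant among the compounds shown, and "the series" means these compounds.

compound 1 `N#Cc1c(-c2ccc(F)cc2)nc2c(/N=N/c3ccc(S(N)(=O)=O)cc3)c(N)nn2c1N` gives 5380 nM
compound 2 `N#Cc1c(-c2ccc(Cl)cc2)nc2c(/N=N/c3ccc(S(N)(=O)=O)cc3)c(N)nn2c1N` gives 11400 nM

Among the measured compounds shown here, in a functional assay on MDA-MB-468 cells (Homo sapiens) for antiproliferative activity, read by MTT assay, with a stated time of 48 h (on this read-out lower numbers stand for stronger inhibition and higher numbers for weaker inhibition), compound 2 gives 11400 nM, the higher of the two numbers so far. Compound 3 `N#Cc1c(-c2ccccc2)nc2c(/N=N/c3ccc(S(N)(=O)=O)cc3)c(N)nn2c1N` departs from it in one place: hydrogen in place of chloro on an aromatic carbon. This puts hydrogen in place of chloro on an aromatic carbon, so that 4-chlorophenyl becomes phenyl. For the measured compounds named here, only one measured step bears on this change: a 2.1-fold higher number from compound 1 to compound 2 (0.33 log units; beyond the scatter). That step is modest and swaps fluoro for chloro at the same place. Going by the values given here, no measured compound carries hydrogen there, so the expectation rests on this single step. In this assay, among the compounds with values here, a modest move toward a lower number is expected, no larger than that step. The estimated change is a 1.8-fold lower number from compound 2 to compound 3 (0.24 log units; within the scatter). Compound 3 is expected at 6500 nM, with an estimated range from 2500 nM to 16000 nM.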

Compound 3, half-maximal inhibitory concentration: 1890 nM
Estimate against measurement, compound 3: 3.4-fold (0.54 log units) above; measured number below the stated range.
By their numbers in this assay, from the lowest: compound 3; then compound 1; then compound 2.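

In this assay, taking the halogen off this aromatic carbon gives a 6.0-fold lower number from compound 2 to compound 3 (0.78 log units; beyond the scatter) and, starting from the fluoro analogue, a 2.8-fold lower number from compound 1 to compound 3 (0.45 log units; beyond the scatter) as well, both beyond the scatter. The earlier pair compared only two halogens, whereas these steps show that neither is needed at this place and that the 4-chlorophenyl to phenyl change moves the number further than the fluoro to chloro swap did. Across these three compounds, hydrogen gives the lowest number, then fluoro, then chloro, and no evidence at hand accounts for that order.

Whether any group at this place can improve on hydrogen remains open, since the only substituents shown are two halogens. A methyl, a methoxy or an amine here might follow the same order or break it.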